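A few compounds are considered here, and "the series" means these few. Any claim that something is new, unique, unknown or untested is made for them only; others in the source may bear on it.

Compound 1 `COc1ncc(-c2ccc3nc(NC(=O)NCCN4CCCCC4)sc3c2)cc1NS(=O)(=O)c1ccc(F)cc1` carries a urea-linked side chain on the shared core, and in a functional assay on MCF7 cells (Homo sapiens) for antiproliferative activity, read by MTT assay, with a stated time of 72 h (a higher number here means a weaker inhibitor, a lower number a stronger inhibitor), compound 1 gives 450 nM. Compound 2 `CCCNc1nc2ccc(-c3cnc(Cl)c(NS(=O)(=O)c4ccc(F)cc4)c3)cc2s1` has a propylamino group on the same position of the core, and in this assay compound 2 is recorded as "not determined" (no result reported), so where it stands cannot be said from the measurements. Compound 3 `CCN(CC)CCNC(=O)Nc1nc2ccc(-c3cnc(Cl)c(NS(=O)(=O)c4ccc(F)cc4)c3)cc2s1` is compound 2 with one group exchanged: (2-(diethylamino)ethyl)carbamoyl in place of propyl on a nitrogen on an aromatic ring. Among the compounds with values here, because compound 2 has no value, the size of the step to compound 3 in this assay cannot be read from measured compounds; only the single result of compound 1, whose side chain is of the same urea type, offers a guide. Compound 3 is therefore expected to fall near compound 1, with an estimated value of 400 nM, the plausible range running from 100 nM to 1600 nM.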

Compound 3, half-maximal inhibitory concentration: 710 nM
Beside the measured number, compound 3's estimate is 1.8-fold (0.25 log units) below it, and the stated range covers the measured number.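

Within the data shown here, with no result for compound 2 in this assay, no step to compound 3 can be read from these compounds. What exchanging the propylamino group for ((2-(diethylamino)ethyl)carbamoyl)amino does to antiproliferative activity therefore stays open, and nothing shown here offers an explanation for the result of compound 3.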